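Working notes: acetamido in place of methylsulfonyl

A few compounds are considered here, and "the series" means these few. Any claim that something is new, unique, unknown or untested is made for them only; others in the source may bear on it.

Compound 1 `CSC[C@H]1O[C@@H](n2cnc3c(N)nc(F)nc32)[C@H](OC(C)=O)[C@@H]1OC(C)=O`: 15000 nM
Compound 2 `C[S+]([O-])C[C@H]1O[C@@H](n2cnc3c(N)nc(F)nc32)[C@H](O)[C@@H]1O`: 13000 nM
Compound 3 `CC(=O)O[C@@H]1[C@H](OC(C)=O)[C@@H](CS(C)(=O)=O)O[C@H]1n1cnc2c(N)nc(Cl)nc21`: 114000 nM

All three values come from an ADME assay on L6 cells (Rattus norvegicus) for inhibition, read by resazurin assay, with a stated time of 72 h; on this read-out higher numbers stand for weaker inhibition and lower numbers for stronger inhibition. Compound 3 gives the highest number of the three, and its distance to each of the other two lies beyond the scatter. Compound 4 `CC(=O)NC[C@H]1O[C@@H](n2cnc3c(N)nc(Cl)nc32)[C@H](OC(C)=O)[C@@H]1OC(C)=O` differs from compound 3 in one place: acetamido in place of methylsulfonyl on a saturated chain carbon bound to a saturated ring carbon. Going by the values given here, no measured pair shows this change alone, so the expectation is loose. Compound 1 gives 15000 nM, which suggests room for a lower number. A moderate move toward stronger inhibition in this assay is expected, with an estimated 2.9-fold lower number from compound 3 to compound 4 (0.45 log units; beyond the scatter). For compound 4 the estimated value is 40000 nM, with an expected range of 12000 nM to 130000 nM.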

Compound 4, half-maximal inhibitory concentration: 190000 nM
For compound 4 the middle estimate is 4.8-fold (0.68 log units) below the measured one, outside the stated range (above it).
By their numbers in this assay, from the lowest: compounds 2 and 1 (each within the scatter of the next); then compounds 3 and 4 (each within the scatter of the next).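

In this assay, acetamido in place of methylsulfonyl on a saturated chain carbon bound to a saturated ring carbon gives a 1.7-fold higher number from compound 3 to compound 4 (0.22 log units; within the scatter) on an otherwise unchanged compound. The swap brings in a hydrogen-bond donor and removes the sulfur, yet the read-out does not separate compound 3 from compound 4 at this position. Nothing on hand offers an explanation for this result.

Still open, on these data alone, is whether an amine or a carboxylic acid at this place would give a different number. As far as these compounds go, a longer chain carrying the acetamido group also remains untested here.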